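A few compounds are considered here, and "the series" means these few. Any claim that something is new, unique, unknown or untested is made for them only; others in the source may bear on it.

Three compounds have been measured in a functional assay on MCF7 cells (Homo sapiens) for antiproliferative activity, read by MTT assay; a lower number here means a stronger inhibitor, a higher number a weaker inhibitor:

compound 1, `COc1ccc(-c2ccnc(Nc3ccc([N+](=O)[O-])cc3)n2)cc1`, gives 770 nM
compound 2, `O=[N+]([O-])c1ccc(Nc2nccc(-c3ccc(Br)cc3)n2)cc1`, gives 681000 nM
compound 3, `COc1ccc(-c2ccnc(Nc3cccc(OC)c3)n2)cc1`, gives 3450 nM

Compound 1 and compound 2 differ in a single place: bromo in place of methoxy on an aromatic carbon. That one change produced an 880-fold higher number from compound 1 to compound 2 (2.95 log units; beyond the scatter), a very large weakening. Compound 4, `COc1cccc(Nc2nccc(-c3ccc(Br)cc3)n2)c1`, has not yet been measured. It stands to compound 3 exactly as compound 2 stands to compound 1, carrying the same change: bromo in place of methoxy on an aromatic carbon. The difference between the core of compound 3 and the core of compound 1 is not broken down here. Compound 3 gives a higher number than compound 1 and a far lower one than compound 2.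

Among the compounds with values here, the expectation for compound 4 rests on an 880-fold higher number from compound 1 to compound 2 (2.95 log units; beyond the scatter), the only earlier example of this change, tempered by the fact that compound 3 has a different core, so a somewhat smaller step is estimated. For compound 4 the expected step is an 87-fold higher number from compound 3 to compound 4 (1.94 log units; beyond the scatter). Compound 4 is therefore expected to give 300000 nM, most likely between 30000 nM and 3000000 nM.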

Compound 4, half-maximal inhibitory concentration: 278000 nM
Estimate against measurement, compound 4: 1.1-fold (0.03 log units) above, and the stated range covers the measured number.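

In this assay, bromo in place of methoxy on an aromatic carbon again gives a much weaker compound (an 81-fold higher number from compound 3 to compound 4 (1.91 log units; beyond the scatter)), so the direction of the change holds on both the core of compound 1 and the core of compound 3. The size of the step does not carry over unchanged, and the gap between the two steps is larger than repeated measurements would explain: the same change on two cores in this assay, an 880-fold higher number (2.95 log units; beyond the scatter) from compound 1 to compound 2 and an 81-fold higher number (1.91 log units; beyond the scatter) from compound 3 to compound 4, 11-fold (1.04 log units) apart, beyond the scatter of two such steps

So the core on which the swap is made matters to how much is lost, but two cores cannot show which feature of them sets the size of the step, or predict it on a third core.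

The compounds shown leave open how other groups would compare at this aromatic carbon, such as chloro, a hydroxyl or an amine, as only methoxy and bromo stand there. They also leave open whether the swap would cost as much on a core carrying a carboxylic acid in place of the nitro or the second methoxy.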